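Replacing the phenoxycarbonyl group of compound 2

A few compounds are considered here, and "the series" means these few. Any claim that something is new, unique, unknown or untested is made for them only; others in the source may bear on it.

Within the data shown here, compound 2 `CS(=O)(=O)c1cnc(O[C@H]2CC[C@H](OC3CCN(C(=O)Oc4ccccc4)CC3)CC2)cn1` is the weaker of the two compounds measured so far in a functional assay on isolated protein for agonist activity at Glucose-dependent insulinotropic receptor (Rattus norvegicus), read by HTRF and cAMP accumulation; on this read-out lower numbers stand for smaller maximal responses and higher numbers for larger maximal responses. In this assay compound 2 gives 104%, the lowest of the two numbers in hand. Among the measured compounds shown here, its only neighbour, compound 1 `CC(C)OC(=O)N1CCC(O[C@H]2CC[C@H](Oc3cnc(S(C)(=O)=O)cn3)CC2)CC1`, gives 120% in this assay. For the measured compounds named here, the single measured step between them, a number 16 percentage points lower from compound 1 to compound 2 (beyond the scatter), comes from swapping an isopropyl group for a phenyl group on an oxygen next to a carbonyl group.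

Compound 3 `CS(=O)(=O)c1cnc(O[C@H]2CC[C@H](OC3CCN(CC4(C(F)(F)F)CCCC4)CC3)CC2)cn1` has not yet been measured in this assay. The change from compound 2 is a group of 10 heavy atoms (7 carbon, 3 fluorine; one five-membered non-aromatic ring of carbon only) in place of a group of 9 heavy atoms (7 carbon, 2 oxygen; one six-membered aromatic ring of carbon only), on an amine nitrogen in a ring. This is a different kind of change from the one already measured, since the whole phenoxycarbonyl group leaves and a group with no hydrogen-bond acceptors enters on the amine nitrogen in a ring. Going by the values given here, no measured step therefore bears directly on it, and the one step that exists was modest. The expected step is accordingly a number 4 percentage points lower from compound 2 to compound 3 (within the scatter), that is, no change beyond the scatter, but with a wide band of uncertainty. Compound 3 is estimated to give 100% in this assay, between 60% and 125%.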

Compound 3, largest response reached (Emax), in percent of the reference or control that the assay uses: 88%
Compound 3: the middle estimate sits 12 percentage points above what was measured; the measured number falls inside the stated range.
By their numbers in this assay, from the lowest: compound 3; then compound 2; then compound 1.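

Compounds 1 and 2 differ only in the group on an oxygen next to a carbonyl group, whereas compound 3 shows what happens when the whole phenoxycarbonyl group leaves the amine nitrogen in a ring. In this assay the new group, which has no hydrogen-bond acceptors, still leaves compound 3 with a clear response of 88% but places it lowest of the three, with a number 16 percentage points lower from compound 2 to compound 3 (beyond the scatter) and, against the isopropyl-bearing compound, a number 32 percentage points lower from compound 1 to compound 3 (beyond the scatter) as the largest step seen so far. No measurement here explains why the maximal response falls with this exchange.

The exchange alters several features at once, since the carbonyl, the oxygen and the aromatic ring all leave while a five-membered carbon ring and fluorine enter, so the compounds shown cannot say which of these changes matters. As far as these compounds go, it remains open how a cyclopentylmethyl group lacking the fluorine atoms, or a benzyl group, on this same nitrogen would compare in this assay with compound 3 and compound 2.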